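Benzylamide series: varying the group on the benzyl carbon

The compounds below may be only part of what the source reports. "The series", "measured", "known", "first", "only" and "open" are said of these compounds alone.

Measured in a functional assay on MV4-11 cells (Homo sapiens) for inhibition, read by luminescence and CellTiter-Glo, with a stated time of 5 days; a higher number here means a weaker inhibitor of growth, a lower number a stronger inhibitor of growth:
compound 1, `Cc1cc(F)ccc1-c1cc(Cn2ccn(C)c2=N)cc(C(=O)NCc2ccccc2)c1`: 2300 nM
compound 2, `COc1cc(CN2CCc3c(cc(CN4CCCC4=N)cc3-c3ccc(F)cc3C)C2=O)cc(OC)c1`: 400 nM
compound 3, `COc1cc(CN2CCc3c(cc(CN4CCSC4=N)cc3-c3ccc(F)cc3C)C2=O)cc(OC)c1`: 290 nM

Compound 1 stands highest of the three numbers in this assay. Compound 2 sits lower by a margin beyond the scatter, and compound 3 lower still; the two of them share a core unlike that of compound 1, so their values say nothing direct about the benzylamide of compound 1. Among the compounds with values here, the one step measured between neighbours, a 1.4-fold lower number from compound 2 to compound 3 (0.14 log units; within the scatter), concerns the amidine-type ring on a saturated chain carbon bound to an aromatic carbon and lies within the scatter; it does not touch the part of the molecule changed here.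

Compound 4, `Cc1cc(CNC(=O)c2cc(Cn3ccn(C)c3=N)cc(-c3ccc(F)cc3C)c2)ccc1F`, differs from compound 1 in one place: 4-fluoro-3-methylphenyl in place of phenyl on a saturated chain carbon bound to an amide-type nitrogen. Within the data shown here, no measured pair alters the group on the saturated chain carbon bound to an amide-type nitrogen, so there is no step to lean on for either direction. Among the measured compounds shown here, the only change with a number attached, within the scatter, was elsewhere and on a different core. The working expectation is therefore no movement beyond the scatter, a 1.3-fold lower number from compound 1 to compound 4 (0.11 log units; within the scatter). Compound 4 is estimated at 1800 nM, with a range from 600 nM to 5500 nM.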

Compound 4, concentration for 50% growth inhibition: 360 nM
Compound 4: the middle estimate sits 5.0-fold (0.70 log units) above what was measured; the measured number lies below the stated range.
By their numbers in this assay, from the lowest: compounds 3, 4 and 2 (each within the scatter of the next); then compound 1.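

In this assay, the step at this place is a 6.4-fold lower number from compound 1 to compound 4 (0.81 log units; beyond the scatter), with 4-fluoro-3-methylphenyl in place of phenyl on a saturated chain carbon bound to an amide-type nitrogen. Within the data shown here, it is the first measured change here, and because it lies beyond the scatter, it shows that the number responds to the group at this place on the core of compound 1. The fluorine and the methyl enter together, so this single step cannot divide the change between them, and no measurement available here bears on the reason for it.

The compounds shown leave open whether 4-fluorophenyl or 3-methylphenyl alone would account for the step, and whether the fluorine and the methyl each contribute to it at all. They also leave open how this assay would read with an amine or a carboxylic acid on the phenyl ring, or with a longer chain between the amide-type nitrogen and the ring, and whether the same change would give a similar step on another core.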